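Replacing a Methoxy Group by a Vinyl Group on the Aryl Ring

This account rests on a few compounds, and the source may have more. Where it says the series, first, only, none or still open, it means among the compounds named here.

Compound 1 `COC1=C(C)C(=O)/C(=C(O)/C=C/c2ccc(OC)cc2)C(=O)C1(C)C` and compound 2 `COC1=C(C)C(=O)/C(=C(O)/C=C/c2ccccc2OC)C(=O)C1(C)C` share the same core and differ only in the aryl group at the end of the chain. In a functional assay on HUVEC cells (Homo sapiens) for cytotoxicity (on this read-out lower numbers stand for an effect already at smaller amounts and higher numbers for an effect only at larger amounts of compound), compound 1 gives 2.5 ug/mL, the larger of the two numbers shown so far, while compound 2 gives 1.7 ug/mL; the step of a 1.5-fold lower number from compound 1 to compound 2 (0.17 log units; within the scatter) lies within the scatter, so the two cannot be told apart. Compound 3 `C=Cc1ccccc1/C=C/C(O)=C1/C(=O)C(C)=C(OC)C(C)(C)C1=O` introduces a new aryl group: 2-vinylphenyl in place of 4-methoxyphenyl on a double-bonded chain carbon bound to a double-bonded chain carbon. For the measured compounds named here, the only measured step, a 1.5-fold lower number from compound 1 to compound 2 (0.17 log units; within the scatter), replaced 4-methoxyphenyl with 2-methoxyphenyl and gave no change beyond the scatter; it bears only loosely on the present change, where a methoxy group leaves and a vinyl group enters. Going by the values given here, with no closer precedent, no step beyond the scatter is expected. Compound 3 is therefore expected to give about 2.5 ug/mL, within 1 ug/mL to 6 ug/mL, an estimated step of no change at the digits printed from compound 1 to compound 3 (within the scatter).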

Compound 3, concentration for half-maximal effect: 1.1 ug/mL
The estimate for compound 3 lay 2.3-fold (0.36 log units) above the measured number; the measured number falls inside the stated range.
By their numbers in this assay, from the lowest: compounds 3, 2 and 1 (each within the scatter of the next, the first and the last beyond it).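

In this assay, for the compounds shown here, exchanging 4-methoxyphenyl for 2-vinylphenyl gives a 2.3-fold lower number from compound 1 to compound 3 (0.36 log units; beyond the scatter), the first step to pass the scatter, so the aryl group at the end of the chain can shift this number, though only modestly. The narrower exchange, vinyl in place of methoxy on an aromatic carbon, gives a 1.5-fold lower number from compound 2 to compound 3 (0.19 log units; within the scatter), so that exchange alone cannot be told apart from the scatter, and the larger step rests on the two end members of a very short series. Nothing measured here explains the difference between these compounds.

From the compounds shown here alone, what an ethyl group in place of the vinyl would do remains open, which leaves the role of the vinyl double bond unsettled. Going by these compounds, the effect of an amine or a carboxylic acid on the aryl ring also remains open.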